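The compounds below may be only part of what the source reports. "The series", "measured", "known", "first", "only" and "open" are said of these compounds alone.

Measured so far:
compound 1 `O=C(CCc1nc2ccccc2c(=O)[nH]1)N/N=C/c1ccc([N+](=O)[O-])cc1` gives 220000000 nM
compound 2 `O=C(CCCc1nc2ccccc2c(=O)[nH]1)N/N=C/c1ccc([N+](=O)[O-])cc1` gives 270000000 nM

In a physicochemical assay, read by spectrophotometry, with a stated time of 6 min (a higher number here means a weaker inhibitor, a lower number a stronger inhibitor), compound 1 stands at 220000000 nM and lies within the scatter of compound 2, so these two numbers give no ranking. Compound 3 `O=C(CCc1nc2ccccc2c(=O)[nH]1)N/N=C/c1ccccc1` has not yet been measured. Going by the values given here, it differs from compound 1 by hydrogen in place of nitro on an aromatic carbon, 4-nitrophenyl to phenyl hydrogen in place of nitro on an aromatic carbon and no measured pair shows this change. No shift beyond the scatter is therefore expected, and no direction is clear. The estimated step of a 1.1-fold higher number from compound 1 to compound 3 (0.04 log units; within the scatter) stays within the scatter. For compound 3 the estimate is 240000000 nM (expected range 100000000 nM to 600000000 nM).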

Compound 3, half-maximal inhibitory concentration: 265000000 nM
Compound 3: middle estimate off by 1.1-fold (0.04 log units), on the low side, within the range that was stated.
By their numbers in this assay, from the lowest: compounds 1, 3 and 2 (each within the scatter of the next).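

In this assay, the change from 4-nitrophenyl to phenyl gives a 1.2-fold higher number from compound 1 to compound 3 (0.08 log units; within the scatter), the first step read at this position. Taking away nitro, with its 3 heavy atoms, therefore leaves the number within the scatter. No available data explain this result or link it to any property of the nitro group.

From the compounds shown here alone, it remains open whether an amine, a carboxylic acid or a methoxy group at this position would give a step beyond the scatter. Going by these compounds, the effect of pairing the phenyl group with a longer chain also remains open.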